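Tert-Butyl for Phenyl on Two Related Cores

A few compounds are considered here, and "the series" means these few. Any claim that something is new, unique, unknown or untested is made for them only; others in the source may bear on it.

Measured compounds:
compound 1, `CC(=O)c1cc(C(=O)c2ccccc2)c(=O)[nH]c1C`, 0%
compound 2, `O=C1CCCc2[nH]c(=O)c(C(=O)c3ccccc3)cc21`, 0%
compound 3, `CC(=O)c1cc(C(=O)C(C)(C)C)c(=O)[nH]c1C`, 0%

In an assay on isolated protein for inhibition of 3',5'-cyclic-AMP phosphodiesterase 4A (Cavia porcellus), read by cAMP accumulation, tested at 1 uM (on this read-out lower numbers stand for a weaker effect and higher numbers for a stronger effect at the one concentration tested), compound 1 gives 0%. Compound 3 carries the change (tert-butyl in place of phenyl on a carbonyl carbon), and the step of no change at the digits printed from compound 1 to compound 3 (within the scatter) shows no movement. Compound 2 gives 0% in this assay, level with both others; the difference between its core and the core of compound 1 is not broken down here.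

Compound 4, `CC(C)(C)C(=O)c1cc2c([nH]c1=O)CCCC2=O`, has not yet been measured. It differs from compound 2 by tert-butyl in place of phenyl on a carbonyl carbon, the same change as between compound 1 and compound 3, made at a place described in the same words. Because the step of no change at the digits printed from compound 1 to compound 3 (within the scatter) stayed flat and compound 2 sits at 0%, the step from compound 2 to compound 4 is expected to be no change at the digits printed from compound 2 to compound 4 (within the scatter). Compound 4 is therefore estimated at 0%, expected to lie between -10% and 10%.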

Compound 4, a percentage reported as inhibition, at one concentration (the size of the read-out at that concentration, not a potency): 0%
Beside the measured number, compound 4's estimate shows no gap at the digits printed; low and high end bracket the measured number.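

On the core of compound 2, tert-butyl in place of phenyl on a carbonyl carbon gives no change at the digits printed from compound 2 to compound 4 (within the scatter) in this assay. Set beside the earlier step, the change reads the same on both cores: the same change on two cores in this assay, no change at the digits printed (within the scatter) from compound 1 to compound 3 and no change at the digits printed (within the scatter) from compound 2 to compound 4, 0 percentage points apart, within the scatter of two such steps. What this does not show is how the change acts on a compound with a real effect: compound 2 gives 0% and compound 4 gives 0%, and flat steps at this level cannot tell whether the swap would raise or lower an inhibition that was present.

Still open, from the compounds shown here alone, is whether another group on that carbonyl carbon, such as an amine or a longer chain, would give any inhibition in this assay on either core.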